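Swapping Fluorophenyl for Hydroxyphenyl on the Shared Core

The compounds below may be only part of what the source reports. "The series", "measured", "known", "first", "only" and "open" are said of these compounds alone.

Compound 1 `COc1cc(-c2nnc3n2NC(c2ccco2)C(C(=O)c2ccccc2F)S3)cc(OC)c1OC` was tested in a functional assay on HepG2 cells (Homo sapiens) for cytotoxicity, read by MTT assay, with a stated time of 48 h; a higher number here means a weaker inhibitor, a lower number a stronger inhibitor. In this assay compound 1 gives only a limit of the assay, > 100000 nM; that is where it stands, at the limit of > 100000 nM in this assay, at which 1 of the 2 values shown sits. A second compound, compound 2 `COc1cc(-c2nnc3n2NC(c2cccs2)C(C(=O)c2ccc(Cl)cc2)S3)cc(OC)c1OC`, differs from compound 1 in more than one place, and in this assay compound 2 gives 13200 nM. Compound 3 `COc1cc(-c2nnc3n2NC(c2ccco2)C(C(=O)c2ccc(O)cc2)S3)cc(OC)c1OC` carries 4-hydroxyphenyl in place of 2-fluorophenyl on a carbonyl carbon. Among the compounds with values here, no measured pair isolates that change, and compound 3 is expected to remain weak, estimated at 80000 nM with a range of 20000 nM to 200000 nM. The expected change, an at least 1.2-fold lower number from compound 1 to compound 3 (0.09 log units; that floor lies within the scatter), is estimated to lie within the scatter.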

Compound 3, half-maximal inhibitory concentration: > 100000 nM
Compound 3 gave a limit, no number; the forecaster's own chance of this, stated with the estimate: 50%; middle value at least 1.2-fold (0.09 log units) from the limit.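

Compound 1 and compound 3 both stop at a limit in this assay, so no step can be read between them: the limit of > 100000 nM in this assay, at which 2 of the 3 values shown sit. The compounds shown leave open whether 4-hydroxyphenyl in place of 2-fluorophenyl on a carbonyl carbon changes the read-out at all.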